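Two Aryl Swaps on the Same Saturated Ring Carbon

This account rests on a few compounds, and the source may have more. Where it says the series, first, only, none or still open, it means among the compounds named here.

Compound 1 `COc1ccc(C2OC(c3cc(OC)c(OC)c(OC)c3)=NN2C(C)=O)c(OC)c1` gives 6.3% in a functional assay on BGC-823 cells (Homo sapiens) for antiproliferative activity, read by MTT assay, tested at 1 uM; on this read-out lower numbers stand for a weaker effect and higher numbers for a stronger effect at the one concentration tested. Compound 2 `COc1cc(C2=NN(C(C)=O)C(c3ccc(C(F)(F)F)cc3)O2)cc(OC)c1OC` gives 4.2% in this assay, the lower of the two numbers, with compound 1 nearest to it; the difference in going a number 2.1 percentage points lower from compound 1 to compound 2 (within the scatter) was a swap of the aryl group on a saturated ring carbon of the shared core, and it stayed within the scatter. Compound 3 `COc1cc(C2=NN(C(C)=O)C(c3ccc(F)c(F)c3)O2)cc(OC)c1OC` changes the same position again: 3,4-difluorophenyl in place of 4-(trifluoromethyl)phenyl on a saturated ring carbon. For the measured compounds named here, the only measured step that bears on this change is the one from compound 1 to compound 2, which was small, so a step of similar size is expected here, with no direction beyond the scatter. Compound 3 is therefore estimated at 5% in this assay, between 0% and 15%, an expected step of a number 0.8 percentage points higher from compound 2 to compound 3 (within the scatter).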

Compound 3, a percentage reported as inhibition, at one concentration (the size of the read-out at that concentration, not a potency): 18.3%
Beside the measured number, compound 3's estimate is 13.3 percentage points below it; measured number above the stated range.
By their numbers in this assay, from the lowest: compounds 2 and 1 (each within the scatter of the next); then compound 3.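

In this assay, the group on this saturated ring carbon now proves able to move the number: 3,4-difluorophenyl in place of 4-(trifluoromethyl)phenyl gives a number 14.1 percentage points higher from compound 2 to compound 3 (beyond the scatter) and 3,4-difluorophenyl in place of 2,4-dimethoxyphenyl gives a number 12 percentage points higher from compound 1 to compound 3 (beyond the scatter). The first two compounds, whose values lie within the scatter of each other, could not show this sensitivity, although the effect at the one concentration tested remains modest. Nothing available explains why the 3,4-difluorophenyl group stands apart from the other two aryl groups.

As far as these compounds go, it remains open whether both fluorines are needed, which 3-fluorophenyl and 4-fluorophenyl groups could help to settle. Also open, from the compounds shown here alone, is how this carbon would respond to a phenyl ring carrying an amine or a carboxylic acid.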